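Swapping hydroxy for fluoro: an expected shift in cytotoxicity

A few compounds are considered here, and "the series" means these few. Any claim that something is new, unique, unknown or untested is made for them only; others in the source may bear on it.

Compound 1 `O=C1CSC(c2cccc(Cl)c2)N1CCN1CCCCC1` gives 31% in an ADME assay on Vero cells (Chlorocebus sabaeus) for cytotoxicity, read by neutral red uptake, tested at 787 ug/mL; a higher number here means a weaker effect of the compound at the concentration tested, a lower number a stronger effect.
Compound 2 `O=C1CSC(c2ccc(O)cc2)N1CCN1CCCCC1` gives 57%.
Compound 3 `O=C1CSC(c2ccccc2[N+](=O)[O-])N1CCN1CCCCC1` gives 100%.

Compound 2 holds the second highest of these three numbers: compound 1 lies nearest and lower, compound 3 furthest and higher, both beyond the scatter. Compound 4 `O=C1CSC(c2ccc(F)cc2)N1CCN1CCCCC1` differs from compound 2 by fluoro in place of hydroxy on an aromatic carbon. Within the data shown here, only one measured step bears on this change, a number 26 percentage points higher from compound 1 to compound 2 (beyond the scatter), in which a halogen gave way to hydroxy. The present change runs the other way, though with a different halogen, so a move back toward a lower number is expected, and the step is estimated as a number 17 percentage points lower from compound 2 to compound 4 (beyond the scatter). Compound 4 is therefore expected to give 40% in this assay, within a range from 20% to 65%.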

Compound 4, a percentage reported as activity, at one concentration (the size of the read-out at that concentration, not a potency): 17%
Compound 4: middle estimate off by 23 percentage points, on the high side; measured number below the stated range.
By their numbers in this assay, from the lowest: compound 4; then compound 1; then compound 2; then compound 3.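

In this assay, fluoro on this aromatic carbon does more than reverse the rise seen with hydroxy, giving a number 40 percentage points lower from compound 2 to compound 4 (beyond the scatter) and also a number 14 percentage points lower from compound 1 to compound 4 (beyond the scatter) in the comparison with the 3-chlorophenyl compound. The halogens are therefore not interchangeable here, although 4-fluorophenyl and 3-chlorophenyl differ in both the halogen and its place on the ring. Nothing measured here accounts for this shift.

As far as these compounds go, whether a methoxy group or an amine on this aromatic carbon would give a number nearer that of compound 2 or that of compound 4 stays open. So does whether fluoro elsewhere on the ring would behave alike.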